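The source may report more compounds than this note shows. Statements on the series, on what has been measured and on what is new or still open speak of the compounds shown alone.

Measured in an assay on isolated protein with Bile acid receptor (Homo sapiens) as the target; a lower number here means that less compound is needed, a higher number that more compound is needed for the effect:
- compound 1 `COC(=O)/C=C/c1cccc(N(Cc2ccc(-c3c(OC)cccc3OC)cc2)C(=O)C2CCCCC2)c1`: 77 nM
- compound 2 `COC(=O)/C=C/c1cccc(N(Cc2ccc(-c3c(OC)cccc3OC)cc2)C(=O)C(C)C)c1`: 95 nM
- compound 3 `COC(=O)/C=C/c1cccc(N(Cc2ccc(/C=C/C(=O)OC(C)(C)C)cc2OC)C(=O)C2CCCCC2)c1`: > 1000 nM, which is a limit of this assay, not a number

Compound 1 gives the lowest of the two numbers; the nearest is compound 2, at a 1.2-fold higher number from compound 1 to compound 2 (0.09 log units; within the scatter), so the two sit within the scatter. Compound 3 stands at the limit of > 1000 nM in this assay, at which 1 of the 3 values shown sits; it differs from compound 1 in two places, so its reading is not a single step.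

Compound 4 `COC(=O)/C=C/c1cccc(N(Cc2ccc(/C=C/C(=O)O)cc2)C(=O)C2CCCCC2)c1` differs from compound 1 by 2-carboxyethenyl in place of 2,6-dimethoxyphenyl on an aromatic carbon. Among the compounds with values here, no measured step bears on this change. Within the data shown here, the only measured step is the cyclohexyl-to-isopropyl swap, within the scatter, and compound 3, which also carries an acrylate-type chain, sits at the limit. Compound 4 is therefore expected to give a higher number in this assay, a step of a 7.8-fold higher number from compound 1 to compound 4 (0.89 log units; beyond the scatter), with an estimate of 600 nM (range 150 nM to 3000 nM).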

Compound 4, half-maximal effective concentration: > 1000 nM
Compound 4 ended at the assay's limit; the forecaster's own chance of this, stated with the estimate: 35%; middle value at least 1.6-fold (0.22 log units) from the limit.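

In this assay, within the data shown here, the 2,6-dimethoxyphenyl group on this aromatic carbon, para to a large group, gives the first single change that lies beyond the scatter: 2-carboxyethenyl in its place gives an at least 12-fold higher number from compound 1 to compound 4 (1.11 log units; beyond the scatter). The reading for compound 4 is a limit of the assay, not a number: the limit of > 1000 nM in this assay, at which 2 of the 4 values shown sit. From the compounds shown here alone, the full size of this step therefore stays unknown.

The compounds shown do not separate loss of the aromatic ring from gain of the acid-bearing chain. An unsubstituted phenyl or a saturated chain ending in an amine at this position would bear on that question.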